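Cyclopentyl in place of tert-butyl: projecting compound 4

The source may report more compounds than this note shows. Statements on the series, on what has been measured and on what is new or still open speak of the compounds shown alone.

Three analogues share one core and differ at a single aromatic carbon. Compound 1 `CCc1c(C)n(C(=O)N2CCCCC2)oc1=O` carries ethyl there, compound 2 `Cc1c(CC(C)C)c(=O)on1C(=O)N1CCCCC1` isobutyl, compound 3 `Cc1c(C(C)(C)C)c(=O)on1C(=O)N1CCCCC1` tert-butyl. In an assay (strain Wistar) for inhibition of Hormone-sensitive lipase (Rattus norvegicus), read by spectrophotometry (on this read-out higher numbers stand for weaker inhibition and lower numbers for stronger inhibition), compound 1 gives 18 nM, compound 2 gives 5 nM, and compound 3 gives 14 nM.

Compound 3 stands second highest of the three. Its nearest neighbour is compound 1: the step of a 1.3-fold lower number from compound 1 to compound 3 (0.11 log units; within the scatter) lies within the scatter, so the two cannot be ordered. Against compound 2 the step of a 2.8-fold higher number from compound 2 to compound 3 (0.45 log units; beyond the scatter) is beyond the scatter, and the step of a 3.6-fold lower number from compound 1 to compound 2 (0.56 log units; beyond the scatter) points the same way, marking isobutyl as the substituent with the lowest number so far.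

Compound 4 `Cc1c(C2CCCC2)c(=O)on1C(=O)N1CCCCC1` is the next step: cyclopentyl in place of tert-butyl on an aromatic carbon. The change is cyclopentyl in place of tert-butyl on an aromatic carbon. Within the data shown here, the steps that bear on it are those to and from the isobutyl and tert-butyl compounds. Since the five-carbon isobutyl of compound 2 gave the lowest number, and cyclopentyl likewise brings five carbons, a modest lowering beyond the scatter is expected for compound 4, of about a 1.8-fold lower number from compound 3 to compound 4 (0.24 log units; within the scatter). The estimate for compound 4 in this assay is therefore 8 nM, with a range from 3 nM to 25 nM.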

Compound 4, half-maximal inhibitory concentration: 6 nM
Beside the measured number, compound 4's estimate is 1.3-fold (0.12 log units) above it; measured number inside the range.
By their numbers in this assay, from the lowest: compounds 2 and 4 (each within the scatter of the next); then compounds 3 and 1 (each within the scatter of the next).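

Among these compounds, at this aromatic carbon, in this assay, a ring can carry the low number that had so far been seen only with the open-chain isobutyl: cyclopentyl sits clear of tert-butyl, with a 2.3-fold lower number from compound 3 to compound 4 (0.37 log units; beyond the scatter), and clear of ethyl, with a 3.0-fold lower number from compound 1 to compound 4 (0.48 log units; beyond the scatter), while a 1.2-fold higher number from compound 2 to compound 4 (0.08 log units; within the scatter) leaves cyclopentyl and isobutyl unordered. The position therefore separates two pairs among the four groups, with isobutyl and cyclopentyl on the low side and tert-butyl and ethyl on the high side, and the extra heavy atom and ring of cyclopentyl relative to tert-butyl go with a real change in the number. Nothing available accounts for this difference between cyclopentyl and tert-butyl.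

Still open, from the compounds shown here alone, is whether a cyclohexyl ring, a phenyl ring or a longer chain such as n-pentyl at this carbon would hold the number at the level of compound 2 and compound 4, or whether a hydroxyl group or an amine on the cyclopentyl ring would be accepted. Also open, going by these compounds, is whether the step from tert-butyl to cyclopentyl keeps its size when an ethyl group replaces the methyl group on the neighbouring ring atom.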